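Dropping Bromine From the Aryl Amine of Compound 1

The compounds below may be only part of what the source reports. "The series", "measured", "known", "first", "only" and "open" are said of these compounds alone.

Compound 1, with the structure `COc1cc2ncnc(Nc3cc(F)ccc3Br)c2c(OC)c1OC`, was tested in a functional assay on PC-3 cells (Homo sapiens) for inhibition, read by MTT assay, with a stated time of 72 h, tested at 1 uM (on this read-out higher numbers stand for more inhibition of growth at the one concentration tested and lower numbers for less inhibition of growth), and gave 12.8%. Of the two measured numbers this is the higher one; the nearest is compound 2, `COc1cc2ncnc(Nc3cc(C(F)(F)F)ccc3Br)c2c(OC)c1OC`, which in this assay gave -3.9%. For the measured compounds named here, the one step between them, a number 16.7 percentage points lower from compound 1 to compound 2 (beyond the scatter), came from putting trifluoromethyl in place of fluoro on an aromatic carbon.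

Compound 3, `COc1cc2ncnc(Nc3ccccc3F)c2c(OC)c1OC`, is a new variant: 2-fluorophenyl in place of 2-bromo-5-fluorophenyl on a nitrogen on an aromatic ring. Going by the values given here, no measured step mirrors this change, because the only step that exists, a number 16.7 percentage points lower from compound 1 to compound 2 (beyond the scatter), altered which group sits on the ring rather than removing bromine. That step does show that a change on this ring can move the read-out by a modest amount, and in the downward direction, which is all the guidance there is.

For compound 3 the expected result in this assay is therefore a small change at most, probably within the scatter: an estimated step of a number 4.8 percentage points lower from compound 1 to compound 3 (within the scatter). The estimated value for compound 3 is 8%, with a likely range from -8% to 22%.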

Compound 3, percent growth inhibition at one concentration: 0.9%
For compound 3 the middle estimate is 7.1 percentage points above the measured one, within the range that was stated.
By their numbers in this assay, from the lowest: compounds 2 and 3 (each within the scatter of the next); then compound 1.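

Replacing 2-bromo-5-fluorophenyl with 2-fluorophenyl on the nitrogen gives a number 11.9 percentage points lower from compound 1 to compound 3 (beyond the scatter) in this assay, so this change lowers the number more than the estimate suggested and takes it beyond the usual scatter. The earlier step altered one group on the ring while bromine stayed in place; this one shows that a change which removes bromine and also gives the fluorine a different number in the group's name can lower the read-out too, so compound 1 now stands above both of its measured neighbours. What lies behind this fall remains unexplained, as no supporting measurement bears on it.

The two differences in this swap are bundled, so the compounds shown cannot tell how much of the step comes from losing bromine and how much from where the fluorine sits, and a 2-bromophenyl group would be the natural way to pull them apart. From the compounds shown here alone, it also remains open how this position would respond to a quite different group on the ring, such as an amine or a carboxylic acid.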